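The source may report more compounds than this note shows. Statements on the series, on what has been measured and on what is new or still open speak of the compounds shown alone.

Working notes on the series. Compound 1 `O=C(O)CCCCCCc1cccc2cncn12` stands at the low end of the numbers obtained so far in an assay for inhibition of Thromboxane-A synthase (Homo sapiens) (a higher number here means a weaker inhibitor, a lower number a stronger inhibitor), where compound 1 gives 5.2 nM. The nearest of the measured compounds is compound 3 `O=C(O)CCCCc1cccn2cncc12`, which in this assay gives 390 nM; this gap lies beyond the scatter. Compound 2 `Cc1ncc2cccc(CCCCCC(=O)O)n12`, a methyl-bearing isomer of the core, is the furthest away: in this assay compound 2 gives 25000 nM, again well beyond the scatter from compound 1.

The next candidate is compound 4 `C/C(=C\CCCCCc1cccc2cncn12)C(=O)O`. Among the measured compounds shown here, its single change from compound 1 is 2-carboxyprop-1-en-1-yl in place of carboxymethyl on a saturated chain carbon, five bonds along the chain from an aromatic carbon. For the measured compounds named here, no measured pair in the set isolates this kind of change, so the size of the step rests on the spread seen between compound 1 and compound 3 alone. A lengthened acid-bearing chain with an added methyl and an additional double bond is expected to cost some potency rather than gain it, with the step of a 5.8-fold higher number from compound 1 to compound 4 (0.76 log units; beyond the scatter) expected to exceed the scatter. Compound 4 is therefore estimated at 30 nM, within a range of 5 nM to 200 nM.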

Compound 4, half-maximal inhibitory concentration: 19 nM
Beside the measured number, compound 4's estimate is 1.6-fold (0.20 log units) above it; the range from low to high includes it.
By their numbers in this assay, from the lowest: compound 1; then compound 4; then compound 3; then compound 2.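

In this assay, among the compounds shown here, 2-carboxyprop-1-en-1-yl in place of carboxymethyl on a saturated chain carbon, five bonds along the chain from an aromatic carbon, gives a 3.7-fold higher number from compound 1 to compound 4 (0.56 log units; beyond the scatter) and is the first single-place change that can be read. The step lies beyond the scatter but is modest, so this position accepts the larger unsaturated group with its carboxylic acid kept, at a limited cost in potency. Nothing on hand bears on the reason for this step.

The compounds shown leave open how much of the step belongs to the methyl and how much to the double bond, since the two enter together. Also open, on these data alone, is whether a primary amide in place of the carboxylic acid would hold the number near that of compound 1.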